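This account rests on a few compounds, and the source may have more. Where it says the series, first, only, none or still open, it means among the compounds named here.

Measured compounds:
Compound 1 `Nc1scc(CN2CCN(c3ccc(OC(F)(F)F)cc3)CC2)c1C(=O)c1ccc(Cl)cc1` — -51%
Compound 2 `Nc1scc(CN2CCN(c3ccc(F)cc3F)CC2)c1C(=O)c1ccc(Cl)cc1` — -66%

In a functional assay on CHO cells with adenosine receptor A1 (Homo sapiens) as the target, read by cAMP accumulation and immunoassay, with a stated time of 6 min, tested at 1 uM (a lower number here means a stronger effect, a higher number a weaker effect of the compound at the concentration tested), compound 1 gives -51% and compound 2 gives -66%. Within the data shown here, the single measured step, a number 15 percentage points lower from compound 1 to compound 2 (beyond the scatter), is the only guide so far. On these two numbers compound 2 stands lowest, and its nearest neighbour is compound 1, a number higher by a margin beyond the scatter.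

Compound 3 `Nc1scc(CN2CCN(c3ccccc3Cl)CC2)c1C(=O)c1ccc(Cl)cc1` has not yet been measured. Relative to compound 2 it differs in one place: 2-chlorophenyl in place of 2,4-difluorophenyl on an amine nitrogen in a ring. Among the measured compounds shown here, the one measured step that bears on this change is the one from compound 1 to compound 2, a number 15 percentage points lower from compound 1 to compound 2 (beyond the scatter), in which the group on an amine nitrogen in a ring was also exchanged, and that step was modest. For the measured compounds named here, the exchange that leads to compound 3 has no direct precedent, so the size of the step of a number 11 percentage points higher from compound 2 to compound 3 (beyond the scatter) is expected to be small and is as likely to lie within the scatter as beyond it. For compound 3 the value in this assay is estimated at -55%, with a range from -75% to -35%.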

Compound 3, a percentage reported as activity, at one concentration (the size of the read-out at that concentration, not a potency): -5.2%
Estimate against measurement, compound 3: 49.8 percentage points below; the whole stated range lies below it.
By their numbers in this assay, from the lowest: compound 2; then compound 1; then compound 3.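

In this assay, the group on the amine nitrogen in the ring turns out to weigh far more than the earlier pair suggested: the step between those two was a number 15 percentage points lower from compound 1 to compound 2 (beyond the scatter), whereas 2-chlorophenyl in place of 2,4-difluorophenyl gives a number 60.8 percentage points higher from compound 2 to compound 3 (beyond the scatter), and 2-chlorophenyl in place of 4-(trifluoromethoxy)phenyl gives a number 45.8 percentage points higher from compound 1 to compound 3 (beyond the scatter). Both of the large steps follow exchanges at the same position, and the 2>3 exchange keeps a six-membered aromatic ring of carbon only, with no hydrogen-bond donors, no hydrogen-bond acceptors and no net charge on either side, so those counted features do not separate the two groups. Nothing at hand explains why this exchange has so large an effect.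

The exchange from compound 2 to compound 3 alters the halogen and the substitution pattern together, so the data cannot tell which of the two matters. Whether a plain phenyl, a 4-chlorophenyl or a 2-fluorophenyl on the same nitrogen would read like compound 2 or like compound 3 remains open, as does how any of these compounds would behave at other concentrations.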